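From 2-chlorophenyl to 3-chlorophenyl: an expected antiproliferative value

This account rests on a few compounds, and the source may have more. Where it says the series, first, only, none or still open, it means among the compounds named here.

Values in a functional assay on B16-F10 cells (Mus musculus) for antiproliferative activity, read by MTT assay, with a stated time of 48 h; a lower number here means a stronger inhibitor, a higher number a weaker inhibitor
- compound 1 `O=C(/C=C/c1ccc(O)c(O)c1)N1CCN(c2ccc(F)cc2)CC1` gives 1.68 ug/mL
- compound 2 `O=C(/C=C/c1ccc(O)c(O)c1)N1CCN(c2ccccc2Cl)CC1` gives 1.82 ug/mL
- compound 3 `O=C(/C=C/c1ccc(O)c(O)c1)N1CCN(c2cccc(Cl)c2)CC1` has not yet been measured

In this assay, among the measured compounds shown here, compound 2 stands level with compound 1, with a 1.1-fold higher number from compound 1 to compound 2 (0.03 log units; within the scatter) as the only measured step. Compound 3 differs from compound 2 by 3-chlorophenyl in place of 2-chlorophenyl on an amine nitrogen in a ring, with 3-chlorophenyl in place of 2-chlorophenyl on an amine nitrogen in a ring. For the measured compounds named here, no measured step isolates this change. The nearest evidence is a 1.1-fold higher number from compound 1 to compound 2 (0.03 log units; within the scatter), which also alters this aryl group. No step beyond the scatter is therefore expected in this assay, and the expected step is a 1.0-fold lower number from compound 2 to compound 3 (0.00 log units; within the scatter). Compound 3 is estimated at 1.8 ug/mL, with an expected range from 0.9 ug/mL to 3.6 ug/mL.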

Compound 3, half-maximal inhibitory concentration: 1.71 ug/mL
Beside the measured number, compound 3's estimate is 1.1-fold (0.02 log units) above it; low and high end bracket the measured number.
By their numbers in this assay, from the lowest: compounds 1, 3 and 2 (each within the scatter of the next).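

In this assay, among the compounds shown here, 3-chlorophenyl in place of 2-chlorophenyl on the amine nitrogen in the ring gives a 1.1-fold lower number from compound 2 to compound 3 (0.03 log units; within the scatter), the first direct comparison of two placements of the chlorine on this aryl group, and the placement makes no difference beyond the scatter. 3-chlorophenyl in place of 4-fluorophenyl gives a 1.0-fold higher number from compound 1 to compound 3 (0.01 log units; within the scatter), so all three aryl groups stand level here. No measurement bears on why these values stand level.

The compounds shown leave open whether an aryl group bearing a carboxylic acid or an amine, or a cyclohexyl group in place of the aryl group, would move the number beyond the scatter.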